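The source may report more compounds than this note shows. Statements on the series, on what has been measured and on what is new or still open speak of the compounds shown alone.

Among the compounds with values here, in a functional assay on K562 cells (Homo sapiens) for cytotoxicity, read by MTT assay, with a stated time of 48 h (on this read-out higher numbers stand for weaker inhibition and lower numbers for stronger inhibition), compound 1 (`CCOC(=O)[C@@]1(C(=O)Nc2ccccc2Cl)C[C@@H]1c1cc(OC)c(OC)c(OC)c1`) gives 49400 nM, the only actual number so far. Compound 2 (`COc1cc([C@H]2C[C@@]2(CO)C(=O)Nc2ccccc2Cl)cc(OC)c1OC`) gives > 100000 nM, which is a limit and not a number. Compound 3 (`CCOC(=O)[C@@]1(C(=O)Nc2ccccc2Cl)C[C@H]1c1cc(OC)c(OC)c(OC)c1`) gives > 100000 nM, which is also a limit and not a number.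

Two measured steps start from compound 1. One is an at least 2.0-fold higher number from compound 1 to compound 2 (0.30 log units; that floor lies within the scatter), with hydroxymethyl in place of ethoxycarbonyl on a saturated ring carbon. The other is an at least 2.0-fold higher number from compound 1 to compound 3 (0.30 log units; that floor lies within the scatter), and for this pair the evidence is the fact that compounds 1 and 3 differ only in the configuration as drawn. Both steps are only floors, set by the limit of > 100000 nM in this assay, at which 2 of the 3 values shown sit.

Compound 4 (`CCOC(=O)[C@@]1(C(=O)NCc2ccc(C)cc2)C[C@@H]1c1cc(OC)c(OC)c(OC)c1`) keeps the core of compound 1 and changes the amide substituent: 4-methylbenzyl in place of 2-chlorophenyl on an amide-type nitrogen. Neither measured step touches this amide-type nitrogen, so neither gives a size for the change. No step beyond the scatter is therefore expected in this assay, and no direction is favoured, so the expectation stays anchored on compound 1 at 49400 nM. The estimated change is a 1.2-fold higher number from compound 1 to compound 4 (0.08 log units; within the scatter). A reported limit in place of a number is also expected to be a real possibility. For compound 4 the estimated value is 60000 nM, with an expected range from 20000 nM to 100000 nM.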

Compound 4, half-maximal inhibitory concentration: > 100000 nM
Compound 4 gave a limit, no number; the forecaster's own chance of this, stated with the estimate: 40%; at least 1.6-fold (0.22 log units) between middle value and limit.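

In this assay the amide-type nitrogen now has a measured change of its own, and compound 4 gives > 100000 nM, which is a limit and not a number. Exchanging 2-chlorophenyl for 4-methylbenzyl at this place gives an at least 2.0-fold higher number from compound 1 to compound 4 (0.30 log units; that floor lies within the scatter), so the exchange shows no gain in this assay, while the true size of the step stays unread. Each single change from compound 1 shown so far, whether to the ethoxycarbonyl group, to the configuration or now to the amide substituent, ends at the same limit, and no compound shown goes against this, which leaves compound 1 as the only compound with a number: the limit of > 100000 nM in this assay, at which 3 of the 4 values shown sit.

The exchange alters the substituents on the aromatic ring and the link between that ring and the nitrogen together, so the compounds shown do not say which of these parts matters, or whether any of them does. A plain benzyl or a 2-chlorobenzyl group on the same nitrogen would separate these parts, and any value below the limit would turn a floor into a readable step.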